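Isobutylcarbamoyl in place of methylcarbamoyl: a solubility step

The compounds below may be only part of what the source reports. "The series", "measured", "known", "first", "only" and "open" are said of these compounds alone.

Measured in a physicochemical assay for solubility (on this read-out lower numbers stand for lower solubility and higher numbers for higher solubility), so far:
- Compound 1 (`CNC(=O)c1cc(C(=O)NCCC2CCOCC2)cn(Cc2ccccc2)c1=O`) gives >= 127 ug/mL as a limit
- Compound 2 (`CNC(=O)c1cccn(Cc2ccccc2)c1=O`) gives 78 ug/mL
- Compound 3 (`CNC(=O)c1cc(C(=O)NC)c(=O)n(Cc2ccccc2)c1`) gives >= 118 ug/mL as a limit

Compound 3 stands at >= 118 ug/mL as a limit and has no exact number. Compound 4 (`CNC(=O)c1cc(C(=O)NCC(C)C)cn(Cc2ccccc2)c1=O`) has not been measured and differs from compound 3 through isopropyl in place of hydrogen on a saturated chain carbon bound to an amide-type nitrogen in one place, with isopropyl in place of hydrogen on a saturated chain carbon bound to an amide-type nitrogen.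

The closest evidence is a step that the two limits leave unreadable from compound 1 to compound 3 at that same place. Compound 1 carries (oxan-4-yl)methyl there and gives >= 127 ug/mL as a limit. The other measured step is an at least 1.5-fold higher number from compound 2 to compound 3 (0.17 log units; that floor lies within the scatter) at a different place, so it bears on this change only weakly. No step beyond the scatter is therefore expected in this assay in either direction, and another limit is quite possible. The expected step is a step that the limit leaves unreadable from compound 3 to compound 4 on this estimate. Compound 4 is estimated at 120 ug/mL with a range from 60 ug/mL to 165 ug/mL as the expected span.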

Compound 4, solubility: 43 ug/mL
The estimate for compound 4 lay 2.8-fold (0.45 log units) above the measured number; the measured number lies below the stated range.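

In this assay, going by these compounds alone, isopropyl in place of hydrogen on a saturated chain carbon bound to an amide-type nitrogen gives the first readable step at this place, an at least 2.7-fold lower number from compound 3 to compound 4 (0.43 log units; beyond the scatter). Isopropyl in place of (oxan-4-yl)methyl at the same place also reads clearly, an at least 2.9-fold lower number from compound 1 to compound 4 (0.47 log units; beyond the scatter), so the groups carried here do not all read alike. The comparison at a different place gives a 1.8-fold lower number from compound 2 to compound 4 (0.26 log units; within the scatter), which shows no change beyond the scatter for that comparison.

On these data alone, compound 3 stands at a limit, so the full size of its step stays open: the limit of >= 118 ug/mL in this assay, at which 1 of the 4 values shown sits. Also open is how a chain ending in an amine or a carboxylic acid would read at this place, and how a longer chain would read there.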